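The source may hold more compounds than are shown below. What is called first, only, known or untested is meant among the compounds shown, and "the series" means these compounds.

The account centres on a series built around one shared core and read in an assay on isolated protein for inhibition of Substance-P receptor (Cavia porcellus), tested at 1 ug/mL; on this read-out higher numbers stand for more inhibition at the one concentration tested (going by the name of the read-out) and lower numbers for less inhibition. Compound 1 `COc1cc(C(=O)N2CO[C@](CCN3CCC(NC(=O)c4ccccc4)CC3)(c3ccc(Cl)c(Cl)c3)C2)cc(OC)c1OC` gives 89%. For the measured compounds named here, compound 3 `COc1cc(C(=O)N2CO[C@](CCN3CCC(C(=O)c4ccc(Cl)cc4)CC3)(c3ccc(Cl)c(Cl)c3)C2)cc(OC)c1OC` gives 97%; the one measured step, a number 8 percentage points higher from compound 1 to compound 3 (within the scatter), lies within the scatter. Compound 2 `COc1cc(C(=O)N2CO[C@](CCN3CCN(c4ncccn4)CC3)(c3ccc(Cl)c(Cl)c3)C2)cc(OC)c1OC` gives 100%, the highest of the three numbers: its gap to compound 3 is within the scatter, its gap to compound 1 beyond it, so the two cannot be ordered against compound 2 with equal confidence.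

Compound 4 `COc1cc(C(=O)N2CO[C@](CCN3CCN(c4ccccn4)CC3)(c3ccc(Cl)c(Cl)c3)C2)cc(OC)c1OC` differs from compound 2 in one place: pyridin-2-yl in place of pyrimidin-2-yl on an amine nitrogen in a ring. Going by the values given here, no measured step touches that position; the only step in hand, from compound 1 to compound 3, alters a different ring and is itself within the scatter. Nothing in the numbers therefore points to a shift beyond the scatter in this assay, and the expected step is a number 4 percentage points lower from compound 2 to compound 4 (within the scatter). For compound 4 the estimate is 96%, with a range from 85% to 100%.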

Compound 4, a percentage reported as inhibition, at one concentration (the size of the read-out at that concentration, not a potency): 100%
The estimate for compound 4 lay 4 percentage points below the measured number, within the range that was stated.
By their numbers in this assay, from the lowest: compounds 1, 3, 2 and 4 (each within the scatter of the next, the first and the last beyond it).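

In this assay, a measured step now reaches the amine nitrogen in the six-membered non-aromatic ring with 2 nitrogen: no change at the digits printed from compound 2 to compound 4 (within the scatter). Pyridin-2-yl, with 1 hetero atom and 1 hydrogen-bond acceptor, thus holds the printed number as well as pyrimidin-2-yl, with 2 hetero atoms and 2 hydrogen-bond acceptors, so at the one concentration tested this read-out does not depend on the second ring nitrogen of pyrimidin-2-yl. No measurement of any property of the two groups bears on this result, and no reason for it can be offered.

Compound 2 and compound 4 both stand at the top of a percentage scale at a single concentration, so any difference in potency between them would stay hidden here. Going by these compounds, what a plain phenyl ring, a methyl group or an acetic acid chain would give on that nitrogen remains open.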